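Methyl Added to the Aryl Triazole Amide

The source may report more compounds than this note shows. Statements on the series, on what has been measured and on what is new or still open speak of the compounds shown alone.

Compound 1, `COc1cc2c(Oc3ccc(NC(=O)c4cn(-c5c(C)cccc5C)nn4)cc3F)ccnc2cc1OCCCN1CCCC1`, in a functional assay on MKN-45 cells (Homo sapiens) for cytotoxicity, read by MTT assay, with a stated time of 72 h; a higher number here means a weaker inhibitor, a lower number a stronger inhibitor: compound 1 gives 3490 nM.
Compound 2, `COc1cc2c(Oc3ccc(NC(=O)c4cn(-c5ccccc5C)nn4)cc3F)ccnc2cc1OCCCN1CCC(C)CC1`, in this assay: compound 2 gives "not determined" (no result reported), so no result was reported for compound 2.

Compound 2 therefore stands nowhere on the numbers shown; its place in this assay is empty, and the only value available is that of compound 1, which shares with compound 2 the core and the amide but differs in two places at once, so the two cannot be set against each other as a single step. Compound 3, `COc1cc2c(Oc3ccc(NC(=O)c4cn(-c5c(C)cccc5C)nn4)cc3F)ccnc2cc1OCCCN1CCC(C)CC1`, takes the change (methyl in place of hydrogen on an aromatic carbon), methyl in place of hydrogen on an aromatic carbon. Going by the values given here, with no measured pair showing the effect of this change in this assay, no step of any size or direction can be expected beyond the scatter. Compound 3 is estimated at 3000 nM, with a range from 900 nM to 10000 nM, because compound 1 gives 3490 nM and carries the same aryl group.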

Compound 3, half-maximal inhibitory concentration: 4310 nM
The estimate for compound 3 lay 1.4-fold (0.16 log units) below the measured number; low and high end bracket the measured number.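

Compound 2 has no number in this assay, and the step from 2-methylphenyl to 2,6-dimethylphenyl therefore cannot be read. Compound 3 instead provides the first readable pair: with the 2,6-dimethylphenyl group held fixed, 4-methylpiperidin-1-yl in place of pyrrolidin-1-yl gives a 1.2-fold higher number from compound 1 to compound 3 (0.09 log units; within the scatter), and the two amine groups cannot be told apart in this assay. No other evidence bears on this result.

Going by these compounds alone, whether the added methyl on the aromatic carbon changes the number in this assay remains open, as no measured pair isolates it. Also open, going by these compounds, is whether chlorine or methoxy in that place, or a morpholine at the end of the chain, would give a step beyond the scatter.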